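Replacing a methoxyphenyl arm with quinoline on a shared core

The compounds below may be only part of what the source reports. "The series", "measured", "known", "first", "only" and "open" are said of these compounds alone.

Of the compounds shown here, three built on one core have been measured in a functional assay on CHOK cells for antagonist activity at growth hormone secretagogue receptor type 1 (Homo sapiens), read by calcium flux; on this read-out higher numbers stand for weaker inhibition and lower numbers for stronger inhibition. Compound 1 `Nc1nc(N)c(-c2ccc(NCc3ccc([N+](=O)[O-])cc3)cc2)c(COCc2ccccc2)n1` gives 5.8 nM, compound 2 `CC(=O)c1ccc(CNc2ccc(-c3c(N)nc(N)nc3COCc3ccccc3)cc2)cc1` gives 10 nM, and compound 3 `COc1ccc(CNc2ccc(-c3c(N)nc(N)nc3COCc3ccccc3)cc2)cc1` gives 90 nM, the highest number of the three. The steps of a 16-fold higher number from compound 1 to compound 3 (1.19 log units; beyond the scatter) and a 9.0-fold higher number from compound 2 to compound 3 (0.95 log units; beyond the scatter) show that the group at the end of the arm on the ring nitrogen changes the number a great deal. Compound 4 `Nc1nc(N)c(-c2ccc(NCc3cnc4ccccc4c3)cc2)c(COCc2ccccc2)n1` carries quinolin-3-yl in place of 4-methoxyphenyl on a saturated chain carbon bound to a nitrogen on an aromatic ring. Within the data shown here, no measured step involves quinoline, so the direction is uncertain; since compound 3 stands at the weak end, an improvement is expected, giving an estimated step of a 3.0-fold lower number from compound 3 to compound 4 (0.48 log units; beyond the scatter). Compound 4 is therefore expected near 30 nM, within 6 nM to 150 nM.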

Compound 4, half-maximal inhibitory concentration: 780 nM
For compound 4 the middle estimate is 26-fold (1.41 log units) below the measured one, outside the stated range (above it).
By their numbers in this assay, from the lowest: compounds 1 and 2 (each within the scatter of the next); then compound 3; then compound 4.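

In this assay, replacing a substituted phenyl with quinolin-3-yl on this saturated chain carbon weakens inhibition in every comparison, with an 8.7-fold higher number from compound 3 to compound 4 (0.94 log units; beyond the scatter) and larger steps against the two stronger compounds, a 78-fold higher number from compound 2 to compound 4 (1.89 log units; beyond the scatter) and a 130-fold higher number from compound 1 to compound 4 (2.13 log units; beyond the scatter) on the same read-out. The position therefore does more than rank groups on a phenyl ring, and compound 4 is the weakest of the four. No available evidence explains this loss.

Going by these compounds, whether it follows from the ring nitrogen or from the added ring remains open. A naphthalen-2-yl or pyridin-3-yl arm at this position would separate the two.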